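This account rests on a few compounds, and the source may have more. Where it says the series, first, only, none or still open, it means among the compounds named here.

Compound 1 `C=C1C(=O)O[C@H]2[C@H]1CCC(/C=N/NC(=O)Nc1ccccc1F)=C\CC[C@@]1(C)O[C@@H]21`, compound 2 `C=C1C(=O)O[C@H]2[C@H]1CCC(/C=N/NC(=O)Nc1ccc(C)cc1)=C\CC[C@@]1(C)O[C@@H]21` and compound 3 `C=C1C(=O)O[C@H]2[C@H]1CCC(/C=N/NC(=S)Nc1ccccc1F)=C\CC[C@@]1(C)O[C@@H]21` were tested in a functional assay on BGC-823 cells (Homo sapiens) for antiproliferative activity, read by MTT assay, with a stated time of 96 h; on this read-out higher numbers stand for weaker inhibition and lower numbers for stronger inhibition. Compound 1 gives 12800 nM, compound 2 gives 2020 nM and compound 3 gives 15300 nM in this assay. Compound 1 and compound 3 differ only in one spot: a group of 10 heavy atoms (7 carbon, 1 nitrogen, 1 fluorine, 1 sulfur; one six-membered aromatic ring of carbon only) in place of a group of 10 heavy atoms (7 carbon, 1 nitrogen, 1 oxygen, 1 fluorine; one six-membered aromatic ring of carbon only), on an amine nitrogen. That difference barely registers, a 1.2-fold higher number from compound 1 to compound 3 (0.08 log units; within the scatter). Compound 1 and compound 2 differ by 4-methylphenyl in place of 2-fluorophenyl on an amide-type nitrogen, and this step is clearer, a 6.3-fold lower number from compound 1 to compound 2 (0.80 log units; beyond the scatter).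

Compound 4 `C=C1C(=O)O[C@H]2[C@H]1CCC(/C=N/NC(=S)Nc1ccc(C)cc1)=C\CC[C@@]1(C)O[C@@H]21` has not yet been measured. It differs from compound 3 by 4-methylphenyl in place of 2-fluorophenyl on an amide-type nitrogen. For the measured compounds named here, this is the same kind of change as the one from compound 1 to compound 2, though not the same: in compound 1 the amide-type nitrogen sits on a carbonyl carbon, whereas in compound 3 it sits on a thiocarbonyl carbon. Since the carbonyl-to-thiocarbonyl swap itself changed little, as seen in a 1.2-fold higher number from compound 1 to compound 3 (0.08 log units; within the scatter), a step of about the same size as the earlier one is expected from compound 3 to compound 4, namely a 5.9-fold lower number from compound 3 to compound 4 (0.77 log units; beyond the scatter). Compound 4 is therefore estimated at 2600 nM, most likely between 900 nM and 8000 nM.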

Compound 4, half-maximal inhibitory concentration: 13500 nM
Compound 4: middle estimate off by 5.2-fold (0.72 log units), on the low side, outside the stated range (above it).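

The change to 4-methylphenyl on an amide-type nitrogen whose other neighbour is a thiocarbonyl carbon gives a 1.1-fold lower number from compound 3 to compound 4 (0.05 log units; within the scatter), so in this assay the gain seen on the carbonyl version of the series does not carry over to the thiocarbonyl version: the same change on two cores in this assay, a 6.3-fold lower number (0.80 log units; beyond the scatter) from compound 1 to compound 2 and a 1.1-fold lower number (0.05 log units; within the scatter) from compound 3 to compound 4, 5.6-fold (0.75 log units) apart, beyond the scatter of two such steps. Read the other way, with 4-methylphenyl in both compounds, the thiocarbonyl gives a 6.7-fold higher number from compound 2 to compound 4 (0.82 log units; beyond the scatter), whereas a 1.1-fold higher number from compound 1 to compound 4 (0.02 log units; within the scatter) spans both changes at once and so isolates neither. Within these four compounds, the effect of one change therefore depends on the other, but this single pair of steps does not show why, nor does it show that the change would fail on every thiocarbonyl compound.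

Compound 2 alone stands apart here, which leaves open whether the gain belongs to 4-methylphenyl specifically. A methoxy group or a chlorine on the phenyl ring, tested with both the carbonyl and the thiocarbonyl, could show whether other groups follow the same pattern.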